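The source may report more compounds than this note shows. Statements on the series, on what has been measured and on what is new or still open speak of the compounds shown alone.

Two carbamates of the shared core have numbers in hand. Compound 1 `Cc1ccccc1NC(=O)OC(CCN(C)C)c1ccc(Cl)cc1` gives 176% in an assay on NIH3T3 cells with Urotensin-2 receptor (Homo sapiens) as the target; on this read-out lower numbers stand for smaller maximal responses and higher numbers for larger maximal responses. Compound 2 `COc1ccc(NC(=O)OC(CCN(C)C)c2ccc(Cl)cc2)cc1` gives 170% in this assay and stands alongside compound 1 within the scatter, the step being a number 6 percentage points lower from compound 1 to compound 2 (within the scatter). Compound 3 `CN(C)CCC(OC(=O)Nc1ccc(C(F)(F)F)cc1)c1ccc(Cl)cc1` differs from compound 2 by trifluoromethyl in place of methoxy on an aromatic carbon. Among the measured compounds shown here, the one measured step on this ring stayed within the scatter, so no shift beyond the scatter is expected for compound 3 in this assay. The estimated step is a number 2 percentage points lower from compound 2 to compound 3 (within the scatter). Compound 3 is expected to give 168% in this assay, within 135% to 200%.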

Compound 3, largest response reached (reported as efficacy), in percent of the reference or control that the assay uses: 94%
Beside the measured number, compound 3's estimate is 74 percentage points above it; the whole stated range lies above it.
By their numbers in this assay, from the lowest: compound 3; then compounds 2 and 1 (each within the scatter of the next).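

The aromatic carbon para to a large group is not a silent position in this assay: trifluoromethyl in place of methoxy gives a number 76 percentage points lower from compound 2 to compound 3 (beyond the scatter) in the maximal response. The earlier step, a number 6 percentage points lower from compound 1 to compound 2 (within the scatter), stayed within the scatter and gave no sign of such sensitivity among these carbamates. Open, going by these compounds, is whether an amine or a nitrile at this same position would stay with methoxy or fall with trifluoromethyl. No evidence at hand accounts for the change.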